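The source may report more compounds than this note shows. Statements on the series, on what has been measured and on what is new or still open speak of the compounds shown alone.

Compound 1 `O=C(/C=C/c1ccco1)Nc1nnc(-c2ccccc2)[nH]1` was tested in an ADME assay on Vero cells (Chlorocebus sabaeus) for cytotoxicity, read by MTT assay, with a stated time of 72 h (a higher number here means that more compound is tolerated, a lower number that less compound is tolerated), and gives 2180000 nM. Its companion, compound 2 `COc1ccc(/C=C/C(=O)Nc2nnc(-c3ccccc3)[nH]2)cc1OC`, gives 1210000 nM in the same test, and the two numbers sit so close together that the gap falls within the usual scatter of repeated measurements. Compound 3 `Nc1ccc(/C=C/C(=O)Nc2nnc(-c3ccccc3)[nH]2)cc1` has not yet been measured; it differs from compound 1 in one place: 4-aminophenyl in place of furan-2-yl on a double-bonded chain carbon bound to a double-bonded chain carbon. Among the compounds with values here, with no measured step of this kind to lean on, the expectation is a change of no more than the scatter in this assay, so the step of a 1.5-fold lower number from compound 1 to compound 3 (0.16 log units; within the scatter) is estimated as small. Compound 3 is thus expected to give about 1500000 nM, plausibly between 500000 nM and 4000000 nM.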

Compound 3, half-maximal cytotoxic concentration: 1910000 nM
For compound 3 the middle estimate is 1.3-fold (0.10 log units) below the measured one, within the range that was stated.
By their numbers in this assay, from the lowest: compounds 2, 3 and 1 (each within the scatter of the next).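

Within the data shown here, replacing furan-2-yl with 4-aminophenyl on a double-bonded chain carbon bound to a double-bonded chain carbon gives a 1.1-fold lower number from compound 1 to compound 3 (0.06 log units; within the scatter) in this assay and is the first single-place step read at this position. Here, a five-membered aromatic ring with 1 hetero atom and a six-membered aromatic ring of carbon only, carrying a hydrogen-bond donor, cannot be told apart. No available measurement gives a reason for this. As far as these compounds go, whether a carboxylic acid in place of furan-2-yl would also stay within the scatter remains open.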